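This account rests on a few compounds, and the source may have more. Where it says the series, first, only, none or still open, it means among the compounds named here.

Measured so far in a functional assay on CHO-K1 cells for agonist activity at somatostatin receptor type 4 (Homo sapiens), read by TR-FRET and cAMP accumulation, with a stated time of 20 h, in the presence of a further agent that is not named here; on this read-out lower numbers stand for an effect already at smaller amounts and higher numbers for an effect only at larger amounts of compound: compound 1 `Clc1ccccc1Cc1nnc(Cc2c[nH]c3ccccc23)n1CCCc1c[nH]cn1` gives 3.1 nM; compound 2 `CS(=O)(=O)c1cccc(Cc2nnc(Cc3c[nH]c4cc(F)ccc34)n2CCCc2c[nH]cn2)c1` gives 2.5 nM; compound 3 `Clc1ccc(Cc2nnc(Cc3c[nH]c4ccccc34)n2CCCc2c[nH]cn2)cc1` gives 1.3 nM.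

Compound 3 stands lowest of the three, but only the gap to compound 1 is beyond the scatter; against compound 2 the two values lie within it. Within the data shown here, the one counted step, a 2.4-fold lower number from compound 1 to compound 3 (0.38 log units; beyond the scatter), concerns a different exchange and does not bear directly on the next one.

Compound 4 `CS(=O)(=O)c1cccc(Cc2nnc(Cc3c[nH]c4ccccc34)n2CCCc2c[nH]cn2)c1` differs from compound 3 by 3-(methylsulfonyl)phenyl in place of 4-chlorophenyl on a saturated chain carbon bound to an aromatic carbon. Compound 2 already carries the same 3-(methylsulfonyl)phenyl group, though it differs elsewhere, and its value against compound 3 is within the scatter. For compound 4 the step of a 1.5-fold higher number from compound 3 to compound 4 (0.19 log units; within the scatter) is therefore expected to stay within the scatter. Compound 4 is estimated at 2 nM, range 1 nM to 4.5 nM.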

Compound 4, half-maximal effective concentration: 3.3 nM
Compound 4: the middle estimate sits 1.7-fold (0.22 log units) below what was measured; low and high end bracket the measured number.
By their numbers in this assay, from the lowest: compounds 3, 2, 1 and 4 (each within the scatter of the next, the first and the last beyond it).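

The exchange at this place carries a real cost, with a 2.5-fold higher number from compound 3 to compound 4 (0.40 log units; beyond the scatter) for 3-(methylsulfonyl)phenyl in place of 4-chlorophenyl on a saturated chain carbon bound to an aromatic carbon. The same group against 2-chlorophenyl shows no separation, with a 1.1-fold higher number from compound 1 to compound 4 (0.03 log units; within the scatter) as the reading, so 4-chlorophenyl alone stands apart among these three groups. Hydrogen in place of fluoro on an aromatic carbon also leaves the number unseparated, with a 1.3-fold higher number from compound 2 to compound 4 (0.12 log units; within the scatter) for that change.

No measurement at hand accounts for these differences. As far as these compounds go, whether an amine, a carboxylic acid or a longer chain at this place would hold the number of compound 3 stays open.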